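The source may report more compounds than this note shows. Statements on the series, on what has been measured and on what is new or still open speak of the compounds shown alone.

Series notes. Compound 1 `Oc1cccc(-c2cc(-c3ccccc3)cc(-c3ccco3)n2)c1` and compound 2 `Oc1cccc(-c2cc(-c3ccccc3)cc(-c3ccncc3)n2)c1` share one core; compound 3 `Oc1ccc(-c2cc(-c3ccccc3)nc(-c3ccco3)c2)cc1` is built from the same atoms joined differently, and the difference between the two cores is not broken down here. In a functional assay on MDA-MB-231 cells (Homo sapiens) for cytotoxicity, read by ELISA, with a stated time of 2 days (a higher number here means a weaker inhibitor, a lower number a stronger inhibitor), compound 1 gives 13700 nM, compound 2 gives 10400 nM and compound 3 gives 1000 nM, the lowest number of the three and beyond the scatter against both others.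

For the measured compounds named here, the one counted step among the measured compounds, (pyridin-4-yl in place of furan-2-yl on an aromatic carbon), gave a 1.3-fold lower number from compound 1 to compound 2 (0.12 log units; within the scatter). Compound 4 `Oc1ccc(-c2cc(-c3ccccc3)nc(-c3ccncc3)c2)cc1` carries the same kind of change relative to compound 3, (pyridin-4-yl in place of furan-2-yl on an aromatic carbon); the place differs in that the carbon is here meta to a 4-hydroxyphenyl group, where in the earlier pair it is meta to a 3-hydroxyphenyl group. With a single prior example, the expectation for compound 4 rests only on that earlier step and on the number given by compound 3 in this assay. The expected step in this assay is a 1.3-fold lower number from compound 3 to compound 4 (0.10 log units; within the scatter), because the earlier step of a 1.3-fold lower number from compound 1 to compound 2 (0.12 log units; within the scatter) stayed within the scatter. Compound 4 is therefore estimated at 800 nM, with an expected range from 300 nM to 2500 nM.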

Compound 4, half-maximal inhibitory concentration: 2100 nM
The estimate for compound 4 lay 2.6-fold (0.42 log units) below the measured number; measured number inside the range.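

In this assay, pyridin-4-yl in place of furan-2-yl on the core of compound 3 gives a 2.1-fold higher number from compound 3 to compound 4 (0.32 log units; beyond the scatter), a modest weakening. Set beside the earlier step, the same change does not carry over unchanged from one core to the other, and the gap between the two steps exceeds the scatter: the same change on two cores in this assay, a 1.3-fold lower number (0.12 log units; within the scatter) from compound 1 to compound 2 and a 2.1-fold higher number (0.32 log units; beyond the scatter) from compound 3 to compound 4, 2.8-fold (0.44 log units) apart, beyond the scatter of two such steps. This shows that, for these two pairs, a step measured on one core is a poor guide to the step on the other, but with one pair per core it does not show how general this is or which feature of the two cores accounts for the gap.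

As far as these compounds go, it remains open whether the gap would persist with other groups on the same aromatic carbon, such as thiophen-2-yl, pyridin-3-yl or an aminomethyl group. From the compounds shown here alone, it is also open how the step would behave with a methoxy group or a carboxylic acid in place of the hydroxyl group.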